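Aryl swap on the benzyl arm of the anilide series

This account rests on a few compounds, and the source may have more. Where it says the series, first, only, none or still open, it means among the compounds named here.

Measured so far:
compound 1 `COC(=O)/C=C/c1cccc(N(Cc2ccc(/C=C/C(=O)O)cc2)C(=O)C2CCCCC2)c1`: 1000 nM
compound 2 `COC(=O)/C=C/c1cccc(N(Cc2ccc(-c3cc(Cl)ccc3OC)cc2)C(=O)C2CCCCC2)c1`: 234 nM

Compound 2 holds the lowest of the two numbers in an assay on isolated protein with Bile acid receptor (Homo sapiens) as the target; a lower number here means that less compound is needed, a higher number that more compound is needed for the effect; its nearest neighbour is compound 1, and the two are separated by the step of a 4.3-fold lower number from compound 1 to compound 2 (0.63 log units; beyond the scatter), which replaced the 2-carboxyethenyl group with the 5-chloro-2-methoxyphenyl group. Compound 3 `COC(=O)/C=C/c1cccc(N(Cc2ccc(-c3ccc(OC(F)(F)F)cc3)cc2)C(=O)C2CCCCC2)c1` is compound 2 with 4-(trifluoromethoxy)phenyl in place of 5-chloro-2-methoxyphenyl on an aromatic carbon, the entering group sitting on an aromatic carbon of a six-membered aromatic ring of carbon only, para to a large group. Among the measured compounds shown here, no measured step bears directly on this exchange: the single step in hand, a 4.3-fold lower number from compound 1 to compound 2 (0.63 log units; beyond the scatter), compares an acid-bearing chain against a biaryl and says nothing about one substituted phenyl against another. The change from compound 2 to compound 3 keeps the biaryl motif and alters only its substitution pattern, so the expected step of a 1.3-fold higher number from compound 2 to compound 3 (0.11 log units; within the scatter) is a small one, not clearly beyond the scatter in either direction. For compound 3 the estimate in this assay is 300 nM, with a range from 100 nM to 1000 nM, the width reflecting the absence of any comparable step.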

Compound 3, half-maximal effective concentration: 263 nM
Compound 3: middle estimate off by 1.1-fold (0.06 log units), on the high side; low and high end bracket the measured number.
By their numbers in this assay, from the lowest: compounds 2 and 3 (each within the scatter of the next); then compound 1.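

In this assay, the step of a 1.1-fold higher number from compound 2 to compound 3 (0.05 log units; within the scatter) stays within the scatter, so this aromatic carbon, para to a large group, carries 5-chloro-2-methoxyphenyl and 4-(trifluoromethoxy)phenyl without a difference that can be read, despite their different substituents. The other new step, a 3.8-fold lower number from compound 1 to compound 3 (0.58 log units; beyond the scatter), lies beyond the scatter and shows that the separation from the 2-carboxyethenyl group of compound 1 is not tied to the 5-chloro-2-methoxyphenyl group alone, since it now appears with a second substituted phenyl group. No supporting data at hand account for either step.

The compounds shown leave open whether an unsubstituted phenyl, a phenyl carrying an amine or a carboxylic acid, or a pyridine ring at this position would stay with compound 2 and compound 3 or move toward compound 1. Also open, going by these compounds, is whether the same tolerance holds when the methyl ester on the other arm is replaced by a carboxylic acid, or the cyclohexyl group on the carbonyl by a smaller ring.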